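A few compounds are considered here, and "the series" means these few. Any claim that something is new, unique, unknown or untested is made for them only; others in the source may bear on it.

Working notes on the series in a functional assay on P388 cells (Mus musculus) for antiproliferative activity, read by colorimetric assay and MTT assay; a higher number here means a weaker inhibitor, a lower number a stronger inhibitor. Compound 1 (`O=S(=O)(Nc1cc(Cl)cc2cc[nH]c12)c1ccc(Cl)cc1`) gives 9.9 ug/mL, compound 2 (`N#Cc1ccc(S(=O)(=O)Nc2ccc(Cl)c3c(Cl)c[nH]c23)cc1`) gives 0.59 ug/mL, and compound 3 (`Nc1ccc(S(=O)(=O)Nc2ccc(Cl)c3c(Cl)c[nH]c23)cc1`) gives 0.49 ug/mL. Compound 3 thus sits at the low end of the numbers, within the scatter of compound 2 and well apart from compound 1.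

Compound 4 (`Nc1ccc(S(=O)(=O)Nc2ccc(Br)c3c(Cl)c[nH]c23)cc1`) differs from compound 3 by one exchange: bromo in place of chloro on an aromatic carbon, bromo in place of chloro, para to a large group. Going by the values given here, no measured pair tests a halogen exchange. Among the compounds with values here, the only measured step, a 1.2-fold lower number from compound 2 to compound 3 (0.08 log units; within the scatter), is an amino for cyano exchange elsewhere, so it bears only weakly on this one. No shift beyond the scatter is expected in this assay, and the expected step is a 1.1-fold lower number from compound 3 to compound 4 (0.04 log units; within the scatter). Compound 4 is estimated at 0.45 ug/mL, with an expected range of 0.2 ug/mL to 1 ug/mL.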

Compound 4, half-maximal inhibitory concentration: 0.64 ug/mL
Estimate against measurement, compound 4: 1.4-fold (0.15 log units) below; the range from low to high includes it.
By their numbers in this assay, from the lowest: compounds 3, 2 and 4 (each within the scatter of the next); then compound 1.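

In this assay, bromo in place of chloro, para to a large group, gives a 1.3-fold higher number from compound 3 to compound 4 (0.12 log units; within the scatter) as the first halogen exchange read in the series. This position therefore accepts either halogen with no shift beyond the scatter, at least with the amino group held constant. No available evidence bears on why the two halogens read alike.

The compounds shown leave open how a methoxy group, a carboxylic acid or plain hydrogen would read at this position. Also open, going by these compounds, is whether the same exchange reads alike with nitrile in place of amino, as in compound 2.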